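Trimming a Methyl on Two Sides of a Shared Core

This account rests on a few compounds, and the source may have more. Where it says the series, first, only, none or still open, it means among the compounds named here.

Compound 1 `CC(/N=c1\c(O)c(O)\c1=N/[C@H](C)C(C)(C)C)c1ccc(C#N)cc1` and compound 2 `C[C@@H](/N=c1\c(O)c(O)\c1=N/Cc1ccc(C#N)cc1)C(C)(C)C` differ in one place: hydrogen in place of methyl on a saturated chain carbon bound to an aromatic carbon and a double-bonded nitrogen. In a functional assay for inhibition, with Rattus norvegicus as the target (a higher number here means a weaker inhibitor, a lower number a stronger inhibitor), compound 1 gives 6500 nM, while compound 2 gives 270 nM, a step of a 24-fold lower number from compound 1 to compound 2 (1.38 log units; beyond the scatter). Compound 3 `CCC(C)(C)/N=c1\c(O)c(O)\c1=N/Cc1ccc(C#N)c(Cl)c1` gives 260 nM in this assay, a number that sits within the usual scatter of compound 2; how the core of compound 3 differs from the core of compound 1 is not broken down here. Compound 4 `CC(C)(C)/N=c1\c(O)c(O)\c1=N/Cc1ccc(C#N)c(Cl)c1` has not been measured and differs from compound 3 by hydrogen in place of methyl on a saturated chain carbon, two bonds along the chain from a double-bonded nitrogen. This is the same kind of change as that from compound 1 to compound 2, but not the same: there the saturated chain carbon was bound to an aromatic carbon and a double-bonded nitrogen, here it lies two bonds along the chain from a double-bonded nitrogen, so the methyl leaves a 1,1-dimethylpropyl group rather than the carbon bound to the aromatic carbon. Because a 24-fold lower number from compound 1 to compound 2 (1.38 log units; beyond the scatter) was made at a different place, that large step is not carried over, and only a small step is expected, a 1.2-fold higher number from compound 3 to compound 4 (0.06 log units; within the scatter). Compound 4 is therefore estimated at 300 nM, with a likely range from 120 nM to 750 nM.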

Compound 4, half-maximal inhibitory concentration: 1100 nM
Beside the measured number, compound 4's estimate is 3.7-fold (0.56 log units) below it, outside the stated range (above it).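

Going from 1,1-dimethylpropyl to tert-butyl gives a 4.2-fold higher number from compound 3 to compound 4 (0.63 log units; beyond the scatter) in this assay, so in this pair losing the methyl makes the inhibitor weaker. Set against the earlier step, this result runs the other way, which means that swapping a methyl for hydrogen cannot be carried from one core to another in this series as a fixed gain: the same change on two cores in this assay, a 24-fold lower number (1.38 log units; beyond the scatter) from compound 1 to compound 2 and a 4.2-fold higher number (0.63 log units; beyond the scatter) from compound 3 to compound 4, 100-fold (2.01 log units) apart, beyond the scatter of two such steps

This does not show that the core alone decides the outcome: the methyl also sits at a different place in the two pairs, and each step rests on a single pair of compounds, so the effects of core and place cannot be told apart.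

Left open is how inhibition would move with a longer chain or a cyclopropyl group in place of the 1,1-dimethylpropyl group. Also open, on these data alone, is what the same methyl-to-hydrogen swap would do at one fixed place on both cores, a comparison that would separate the effect of the core from the effect of the place.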